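Shifting the furan attachment point in the triaryl series

The compounds below may be only part of what the source reports. "The series", "measured", "known", "first", "only" and "open" are said of these compounds alone.

Compound 1 `Oc1ccc(-c2cc(-c3ccco3)cc(-c3ccccc3O)n2)cc1` stands at the limit of a functional assay on HCT-15 cells (Homo sapiens) for cytotoxicity, read by CCK-8 assay (on this read-out lower numbers stand for stronger inhibition and higher numbers for weaker inhibition), giving > 50000 nM, which is a limit of the assay rather than a number; the same limit appears as the limit of > 50000 nM in this assay, at which 1 of the 3 values shown sits, so on the values shown compound 1 is the weakest-resolved member. Its two measured neighbours move the hydroxyl around one phenyl ring: compound 2 `Oc1ccc(-c2cc(-c3ccco3)cc(-c3cccc(O)c3)n2)cc1` gives 840 nM and compound 3 `Oc1ccc(-c2cc(-c3ccco3)cc(-c3ccc(O)cc3)n2)cc1` gives 14000 nM. Those steps are an at least 59-fold lower number from compound 1 to compound 2 (1.77 log units; beyond the scatter), an at least 3.5-fold lower number from compound 1 to compound 3 (0.55 log units; beyond the scatter) and a 17-fold higher number from compound 2 to compound 3 (1.22 log units; beyond the scatter), all of them changes to the hydroxyphenyl and none to the furan.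

Compound 4 `Oc1ccc(-c2cc(-c3ccoc3)cc(-c3ccccc3O)n2)cc1` differs from compound 1 by furan-3-yl in place of furan-2-yl on an aromatic carbon. Among the compounds with values here, no measured step in this assay touches the furan, so none of the three bears directly on the change; the only anchor is compound 1 itself, which sits at the limit. With the two hydroxyphenyl groups unchanged from compound 1, the expectation is that compound 4 stays at or near that limit, with no step beyond the scatter, so a number no higher from compound 1 to compound 4 (the limit leaves the size open) is the expected step. Compound 4 is therefore estimated at 50000 nM, in the range 15000 nM to 150000 nM, most likely reported again as a limit.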

Compound 4, half-maximal inhibitory concentration: > 50000 nM
Compound 4: a limit, no number (the forecaster's own chance of this, stated with the estimate: 70%); the middle value sits exactly at the limit.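

In this assay compound 4 gives > 50000 nM, which is a limit and not a number. Compound 1 sits at the same limit, so the step between compound 1 and compound 4 cannot be read. The compounds shown leave open whether furan-3-yl in place of furan-2-yl changes the read-out in a compound with a readable number, such as compound 2.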